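A Methoxy Gives Way to Trifluoromethyl

A few compounds are considered here, and "the series" means these few. Any claim that something is new, unique, unknown or untested is made for them only; others in the source may bear on it.

Measured compounds:
compound 1, `COc1cc(Nc2ncc(C(F)(F)F)c(N3Cc4cccc(N(C)S(C)(=O)=O)c4C3)n2)cc(OC)c1` — 1800 nM
compound 2, `CC(=O)N1CCN(c2ccc(Nc3ncc(C(F)(F)F)c(N4Cc5cccc(N(C)S(C)(=O)=O)c5C4)n3)cc2)CC1` — 1400 nM
compound 3, `CN(c1cccc2c1CN(c1nc(Nc3cccc(Oc4ccccc4)c3)ncc1C(F)(F)F)C2)S(C)(=O)=O` — 23000 nM

Three compounds sharing the same core were tested in a functional assay on HepG2 cells (Homo sapiens) for antiproliferative activity, read by spectrophotometry, with a stated time of 2 days; on this read-out lower numbers stand for stronger inhibition of growth and higher numbers for weaker inhibition of growth. Compound 1 stands second highest of the three numbers. Its nearest neighbour is compound 2, whose value lies within the scatter of that of compound 1, so the two cannot be told apart. Compound 3 lies furthest away, with a much higher number that is beyond the scatter.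

The step now followed goes from compound 1 to compound 4, `COc1cc(Nc2ncc(C(F)(F)F)c(N3Cc4cccc(N(C)S(C)(=O)=O)c4C3)n2)cc(C(F)(F)F)c1`, which has not yet been measured in this assay. The change is trifluoromethyl in place of methoxy on an aromatic carbon. Among the compounds with values here, no measured pair shows this change, so its size is unknown. Compound 4 is expected to stay near compound 1, with a step of a 1.4-fold higher number from compound 1 to compound 4 (0.14 log units; within the scatter) in this assay, a modest shift toward a higher number that may not exceed the scatter. The estimate for compound 4 is 2500 nM, in a range from 800 nM to 8000 nM.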

Compound 4, concentration for 50% growth inhibition: 22100 nM
Compound 4: the middle estimate sits 8.8-fold (0.95 log units) below what was measured; measured number above the stated range.
By their numbers in this assay, from the lowest: compounds 2 and 1 (each within the scatter of the next); then compounds 4 and 3 (each within the scatter of the next).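

Putting trifluoromethyl in place of one methoxy on this aromatic carbon gives a 12-fold higher number from compound 1 to compound 4 (1.09 log units; beyond the scatter) in this assay, which means weaker inhibition of growth. Compounds 1 to 3 differ from one another in more than one place and could not isolate any single change, whereas this pair shows that growth inhibition in these cells is sensitive to the group at this one position of the 3,5-dimethoxyphenyl ring. Nothing available accounts for the size of this step.

From the compounds shown here alone, it remains open whether the step comes from losing the methoxy or from gaining the trifluoromethyl, which a plain hydrogen, a chlorine or an amine on the same carbon could help to separate. Also open, going by these compounds, is whether the remaining methoxy matters in the same way.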